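A few compounds are considered here, and "the series" means these few. Any claim that something is new, unique, unknown or untested is made for them only; others in the source may bear on it.

Working notes on the amide side chain of the shared core. In a functional assay on BXPC-3 cells (Homo sapiens) for antiproliferative activity, read by MTT assay, with a stated time of 24 h (on this read-out lower numbers stand for stronger inhibition and higher numbers for weaker inhibition), compound 1 `CCn1c(C(=O)NCCNC(=O)OC(C)(C)C)ccc1C(CC)(CC)c1ccc(OCS(=O)(=O)c2ccccc2)c(C)c1` is reported only as a limit, > 50000 nM. Compound 2 `CCn1c(C(=O)NCCCO)ccc1C(CC)(CC)c1ccc(OCS(=O)(=O)c2ccccc2)c(C)c1` gives 26600 nM. Compound 3 `CCn1c(C(=O)N[C@@H](C)C(=O)O)ccc1C(CC)(CC)c1ccc(OCS(=O)(=O)c2ccccc2)c(C)c1` gives 20800 nM. Among the compounds with values here, these last two are the only actual numbers in the set, and they cannot be ordered: the step joining them is a 1.3-fold lower number from compound 2 to compound 3 (0.11 log units; within the scatter). Against the limit, the steps are an at least 1.8-fold lower number from compound 1 to compound 2 (0.27 log units; that floor lies within the scatter) and an at least 2.4-fold lower number from compound 1 to compound 3 (0.38 log units; beyond the scatter).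

Compound 4 `CCn1c(C(=O)N[C@@H](CC(=O)O)C(=O)O)ccc1C(CC)(CC)c1ccc(OCS(=O)(=O)c2ccccc2)c(C)c1` differs from compound 3 at one place: carboxy in place of hydrogen on a saturated chain carbon, two bonds along the chain from an amide-type nitrogen and a carbonyl carbon. This is carboxy in place of hydrogen on a saturated chain carbon, two bonds along the chain from an amide-type nitrogen and a carbonyl carbon, so 1-carboxyethyl becomes 1,2-dicarboxyethyl.

Within the data shown here, no measured step adds a second carboxy group. The closest guide is the entry of 1-carboxyethyl in compound 3, which moved the number only within the scatter relative to 3-hydroxypropyl. The steps from the limit of compound 1 fix no size. No step beyond the scatter is therefore expected in this assay, and the estimated step is a 1.1-fold higher number from compound 3 to compound 4 (0.02 log units; within the scatter). For compound 4 the expected value is 22000 nM, with an estimated range of 10000 nM to 50000 nM.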

Compound 4, half-maximal inhibitory concentration: > 50000 nM
Compound 4: only a limit was reported; the forecaster's own chance of this, stated with the estimate: 20%; middle value at least 2.2-fold (0.35 log units) from the limit.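

In this assay compound 4 is reported only as a limit, > 50000 nM. Within the data shown here, this is the first single change made on the 1-carboxyethyl side chain itself, and carboxy in place of hydrogen on a saturated chain carbon, two bonds along the chain from an amide-type nitrogen and a carbonyl carbon, gives an at least 2.4-fold higher number from compound 3 to compound 4 (0.38 log units; beyond the scatter), so this position does not accept the change without a readable loss of activity, whereas the swap of 3-hydroxypropyl for 1-carboxyethyl had left the number within the scatter; against the 3-hydroxypropyl side chain the result is less firm, at an at least 1.8-fold higher number from compound 2 to compound 4 (0.27 log units; that floor lies within the scatter), and the step that joins the two limits cannot be read. The size of the loss is bounded on one side only, and the top of the range now holds the 1,2-dicarboxyethyl side chain as well as the side chain carrying (tert-butoxycarbonyl)amino: the limit of > 50000 nM in this assay, at which 2 of the 4 values shown sit.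

From the compounds shown here alone, how far compound 4 lies past its limit remains open. Also open, going by these compounds, is whether the loss belongs to a second carboxylic acid as such or to this one position, which a methyl ester or a primary carboxamide at the same carbon, or a longer chain carrying the second carboxylic acid, would help to separate.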